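The compounds below may be only part of what the source reports. "The series", "measured", "known", "first", "only" and "open" are said of these compounds alone.

Compound 1 `CNS(=O)(=O)c1ccc(-c2cnc(N)c(-c3ccc(OC)nc3)c2)cc1` is one of three measured members of a shared core. In a physicochemical assay for solubility, read by nephelometry, measured as kinetic solubility, at pH 2 (a lower number here means a less soluble compound, a higher number a more soluble compound), compound 1 gives > 100 ug/mL, which is a limit of the assay rather than a number. Compound 2 `COc1ccc(-c2cc(-c3ccc(NS(C)(=O)=O)cc3)cnc2N)cn1` carries methanesulfonamido in place of the methylsulfamoyl of compound 1 on an aromatic carbon. In this assay compound 2 gives > 100 ug/mL, again only a limit. Compound 3 `COc1ccc(-c2cc(-c3ccc(S(C)(=O)=O)cc3C(F)(F)F)cnc2N)cn1` likewise reaches a limit in this assay, where compound 3 gives > 100 ug/mL. The step that the two limits leave unreadable from compound 1 to compound 2 cannot be sized because of the limit of > 100 ug/mL in this assay, at which 3 of the 3 values shown sit. Compound 1 therefore stands only at a limit, and nothing on the numbers shown separates it from the other two.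

Compound 4 `COc1ccc(-c2cc(-c3ccc(-n4cncn4)cc3)cnc2N)cn1` differs from compound 1 by 1H-1,2,4-triazol-1-yl in place of methylsulfamoyl on an aromatic carbon. For the measured compounds named here, no measured step bears directly on this exchange: the single measured step, that from compound 1 to compound 2, is unreadable, and all three measured values sit at the same limit. With every measured value at that limit, compound 4 is expected to land at or near it as well, so the expected step of a number no higher from compound 1 to compound 4 (the limit leaves the size open) is one of no readable size. The estimate for compound 4 in this assay is 100 ug/mL, with a range from 30 ug/mL to 200 ug/mL.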

Compound 4, solubility: > 100 ug/mL
Compound 4 ended at the assay's limit; the forecaster's own chance of this, stated with the estimate: 70%; the middle value lies on the limit itself.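

The steps to compound 4 from compound 1 and from compound 2 cannot be read, and no new comparison follows from this result: the limit of > 100 ug/mL in this assay, at which 4 of the 4 values shown sit.

The compounds shown leave open how far each lies past that limit in this assay, and whether methylsulfamoyl, methanesulfonamido and 1H-1,2,4-triazol-1-yl differ at all there.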